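This account rests on a few compounds, and the source may have more. Where it says the series, first, only, none or still open, it means among the compounds named here.

Within the data shown here, compound 3 `CCCNC(=O)c1cc(Oc2ccc(NC(=O)c3cc4cccnc4n(-c4ccc(Cl)cc4)c3=O)cc2)ccn1` gives 120 nM in a functional assay on A549 cells (Homo sapiens) for antiproliferative activity, read by MTT assay, with a stated time of 72 h (on this read-out lower numbers stand for stronger inhibition and higher numbers for weaker inhibition), and stands lowest of the three numbers so far; compound 1 `CNC(=O)c1cc(Oc2ccc(NC(=O)c3cc4cccnc4n(-c4ccc(Cl)cc4)c3=O)cc2)ccn1` gives 370 nM, and compound 2 `CNC(=O)c1cc(Oc2ccc(NC(=O)c3cc4cccnc4n(-c4ccc(F)c(Cl)c4)c3=O)cc2)ccn1` gives 1560 nM. Compound 4 `CCCNC(=O)c1cc(Oc2ccc(NC(=O)c3cc4cccnc4n(-c4ccc(F)c(Cl)c4)c3=O)cc2)ccn1` differs from compound 3 in one place: 3-chloro-4-fluorophenyl in place of 4-chlorophenyl on an aromatic nitrogen. The same change has been measured once, as a 4.2-fold higher number from compound 1 to compound 2 (0.62 log units; beyond the scatter), while the other step, a 3.1-fold lower number from compound 1 to compound 3 (0.49 log units; beyond the scatter), concerns the propyl chain and does not bear on this pair. Among the measured compounds shown here, the single precedent points to a higher number, beyond the scatter, so for compound 4 a step of a 4.2-fold higher number from compound 3 to compound 4 (0.62 log units; beyond the scatter) is expected. Compound 4 is therefore estimated at 500 nM in this assay, within a range of 200 nM to 1300 nM.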

Compound 4, half-maximal inhibitory concentration: 590 nM
Beside the measured number, compound 4's estimate is 1.2-fold (0.07 log units) below it, and the stated range covers the measured number.
By their numbers in this assay, from the lowest: compound 3; then compounds 1 and 4 (each within the scatter of the next); then compound 2.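

The cost of 3-chloro-4-fluorophenyl in place of 4-chlorophenyl on the aromatic nitrogen also appears with the propyl amide, as a 4.9-fold higher number from compound 3 to compound 4 (0.69 log units; beyond the scatter): the same change on two cores in this assay, a 4.2-fold higher number (0.62 log units; beyond the scatter) from compound 1 to compound 2 and a 4.9-fold higher number (0.69 log units; beyond the scatter) from compound 3 to compound 4, 1.2-fold (0.07 log units) apart, within the scatter of two such steps.
The gain from the longer amide chain likewise survives with 3-chloro-4-fluorophenyl in place, as a 2.6-fold lower number from compound 2 to compound 4 (0.42 log units; beyond the scatter): the same change on two cores in this assay, a 3.1-fold lower number (0.49 log units; beyond the scatter) from compound 1 to compound 3 and a 2.6-fold lower number (0.42 log units; beyond the scatter) from compound 2 to compound 4, 1.2-fold (0.07 log units) apart, within the scatter of two such steps.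
Across compounds 1 to 4, the two changes therefore act about independently, and no compound goes against this.

The compounds shown do not separate the moved chlorine from the added fluorine, a question that 3-chlorophenyl or 4-fluorophenyl would address. As far as these compounds go, how far the chain gain extends to a butyl chain or a chain ending in an amine also stays open.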